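Bromo for Fluoro: Estimating the Cytotoxicity of Compound 3

The source may hold more compounds than are shown below. What is called first, only, known or untested is meant among the compounds shown, and "the series" means these compounds.

Compound 1, `O=c1[nH]c2ccccc2cc1-c1nc2cc(Br)ccc2[nH]1`, gives 11400 nM in a functional assay on SK-OV-3 cells (Homo sapiens) for cytotoxicity, read by MTT assay, with a stated time of 48 h; on this read-out lower numbers stand for stronger inhibition and higher numbers for weaker inhibition. Compound 2, `Cc1ccc2[nH]c(=O)c(-c3nc4cc(F)ccc4[nH]3)cc2c1`, reaches only the limit of > 100000 nM in this assay, so no exact number exists for it.

Of the two measured compounds, compound 2 therefore stands at the limit of > 100000 nM in this assay, at which 1 of the 2 values shown sits, the weaker end of what has been seen. Compound 3, `Cc1ccc2[nH]c(=O)c(-c3nc4cc(Br)ccc4[nH]3)cc2c1`, has not yet been measured. It differs from compound 2 by bromo in place of fluoro on an aromatic carbon. Among the measured compounds shown here, no measured pair shows this exact change on its own, so the size of the step can only be guessed. Compound 1 carries the same bromo and gives a real number, while compound 2 carries the fluoro and only a limit; that suggests the change could move toward stronger inhibition, though a step hidden within the scatter cannot be ruled out. Compound 3 is expected to give an estimate of 35000 nM in this assay, within a range from 10000 nM to 120000 nM. The step from compound 2 to compound 3 is expected to be an at least 2.8-fold lower number from compound 2 to compound 3 (0.45 log units; beyond the scatter).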

Compound 3, half-maximal inhibitory concentration: > 100000 nM
Compound 3 ended at the assay's limit; the forecaster's own chance of this, stated with the estimate: 40%; middle value at least 2.8-fold (0.45 log units) from the limit.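

The clearer reading concerns methyl in place of hydrogen on an aromatic carbon: with bromo present in both compounds, this single change in this assay gives an at least 8.7-fold higher number from compound 1 to compound 3 (0.94 log units; beyond the scatter). The earlier compounds shown here could not show this, as they differed in more than one place, and it means the methyl goes with weaker inhibition here, at least on this one pair. By contrast, bromo in place of fluoro does not bring a readable number on the methyl-bearing core, and the step between the two halogens cannot be read, since both compounds rest on the same limit of the assay: the limit of > 100000 nM in this assay, at which 2 of the 3 values shown sit.

What the halogen swap does on its own therefore remains unknown, as any difference between the two compounds could lie hidden beyond that limit, and the fluoro version of the core without the methyl is absent from the compounds shown. Also open, on these data alone, is whether an amine or a carboxylic acid at the halogen's place, or a longer chain at the methyl's place, would give a readable value on this core.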